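Swapping Hydroxymethyl for Ethynyloxy on Compound 2

The compounds below may be only part of what the source reports. "The series", "measured", "known", "first", "only" and "open" are said of these compounds alone.

Three compounds have numbers in an ADME assay on L1210/0 cells (Mus musculus) for cytotoxicity, with a stated time of 48 h; on this read-out higher numbers stand for weaker inhibition and lower numbers for stronger inhibition. Compound 1 `CO[C@@H]1OC[C@@H](OC(C)=O)[C@@H](OC(C)=O)[C@]1(F)n1ccc(=O)[nH]c1=O` gives 55000 nM in this assay. Compound 2 `O=c1[nH]c(=O)n([C@H]2C[C@H](O)[C@@H](CO)O2)cc1CO` gives 9180 nM in this assay, the lowest of the two numbers shown, with compound 1 standing higher by a margin beyond the usual scatter. For compound 3 `Nc1nc2c(nc(O)n2COCCO)c(=O)[nH]1` the read-out in this assay is a limit of the assay, > 200000 nM, not a number. Compound 4 `C#COc1cn([C@H]2C[C@H](O)[C@@H](CO)O2)c(=O)[nH]c1=O` remains to be measured; it differs from compound 2 in one place: ethynyloxy in place of hydroxymethyl on an aromatic carbon. Going by the values given here, with no measured step to guide it, the author expects the change from compound 2 to compound 4 to shift this assay only modestly toward weaker inhibition, by a 2.7-fold higher number from compound 2 to compound 4 (0.44 log units; beyond the scatter). Compound 4 is accordingly estimated at 25000 nM, within 3000 nM to 200000 nM.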

Compound 4, half-maximal inhibitory concentration: > 200000 nM
Compound 4: only a limit was reported; the forecaster's own chance of this, stated with the estimate: 15%; middle value at least 8.0-fold (0.90 log units) from the limit.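

In this assay, going by these compounds alone, the earlier compounds offered no step, and this one gives the first reading of a single change: ethynyloxy in place of hydroxymethyl on an aromatic carbon brings an at least 21-fold higher number from compound 2 to compound 4 (1.33 log units; beyond the scatter). The group on this carbon therefore matters greatly to the read-out, and this swap moves it toward weaker inhibition. For compound 4 the reading is a limit of the assay, not a number: the limit of > 200000 nM in this assay, at which 2 of the 4 values shown sit.

On these data alone, what remains open is whether a smaller methoxy group, an ethyl chain or an amine on this carbon would keep the read-out close to that of compound 2. The compounds shown also cannot separate the loss of hydroxymethyl from the arrival of ethynyloxy.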